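Replacing Bromo with Methyl on the Pendant Phenyl

This account rests on a few compounds, and the source may have more. Where it says the series, first, only, none or still open, it means among the compounds named here.

Compound 2 `O=C(Nc1ccc(Oc2ccnc3[nH]ccc23)cc1)c1cc(-c2ccc(Br)cc2)ncn1` holds the lower of the two numbers measured in a functional assay on PC-3 cells (Homo sapiens) for cytotoxicity, read by MTT assay, with a stated time of 72 h (a higher number here means a weaker inhibitor, a lower number a stronger inhibitor), where compound 2 gives 2610 nM, while compound 1 `O=C(Nc1ccc(Oc2ccnc3[nH]ccc23)cc1)c1cc(-c2ccc(Cl)cc2)ncn1` gives 15600 nM. For the measured compounds named here, the only measured step, a 6.0-fold lower number from compound 1 to compound 2 (0.78 log units; beyond the scatter), exchanged one halogen for another. Going by the values given here, compound 3 `Cc1ccc(-c2cc(C(=O)Nc3ccc(Oc4ccnc5[nH]ccc45)cc3)ncn2)cc1` differs from compound 2 by methyl in place of bromo on an aromatic carbon, a change that removes the halogen entirely and has no measured counterpart, so its direction is uncertain. Compound 3 is therefore expected to land close to compound 2, with an estimated step of a 1.5-fold higher number from compound 2 to compound 3 (0.19 log units; within the scatter). The estimate for compound 3 is 4000 nM, within a range of 1300 nM to 13000 nM.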

Compound 3, half-maximal inhibitory concentration: 9880 nM
Estimate against measurement, compound 3: 2.5-fold (0.39 log units) below; the range from low to high includes it.
By their numbers in this assay, from the lowest: compound 2; then compounds 3 and 1 (each within the scatter of the next).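

Swapping bromo for methyl at this position gives a 3.8-fold higher number from compound 2 to compound 3 (0.58 log units; beyond the scatter) in this assay, so the advantage of bromo holds against a non-halogen group as well as against chloro. Methyl and chloro are not separated, with a 1.6-fold lower number from compound 1 to compound 3 (0.20 log units; within the scatter), so among the three groups shown only bromo stands apart. From the compounds shown here alone, whether iodo, methoxy or an amine at this position would match bromo stays open. No measurement offered here explains why bromo differs from the other two groups.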